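The source may hold more compounds than are shown below. What is called first, only, known or untested is meant among the compounds shown, and "the series" means these compounds.

Three compounds have been measured in an ADME assay on CCRF-CEM cells (Homo sapiens) for cytotoxicity, with a stated time of 72 h; a higher number here means a weaker inhibitor, a lower number a stronger inhibitor:

Compound 1 `Clc1ccc(Cc2nn3cc(-c4ccc(Br)cc4)nc3s2)cc1` gives > 250000 nM, a limit of the assay rather than a number.
Compound 2 `Cc1ccc(-c2cn3nc(Cc4ccc(Cl)cc4)sc3n2)cc1` gives > 250000 nM, likewise a limit.
Compound 3 `Clc1ccc(Cc2nn3cc(-c4ccc(Cl)cc4Cl)nc3s2)cc1` gives > 250000 nM, again a limit.

Compound 3 thus stands only at a limit in this assay, as do the other two; (the limit of > 250000 nM in this assay, at which 3 of the 3 values shown sit). The steps among them, a step that the two limits leave unreadable from compound 1 to compound 2, a step that the two limits leave unreadable from compound 1 to compound 3 and a step that the two limits leave unreadable from compound 2 to compound 3, are all unreadable. Compound 4 `O=Cc1c(-c2ccc(Cl)cc2Cl)nc2sc(Cc3ccc(Cl)cc3)nn12` differs from compound 3 by formyl in place of hydrogen on an aromatic carbon. For the measured compounds named here, no measured step bears readably on this change, and no direction can be drawn from the values. Compound 4 is expected to show no step beyond the scatter, a number no higher from compound 3 to compound 4 (the limit leaves the size open). Compound 4 is therefore estimated at about 250000 nM, with a range from 100000 nM to 600000 nM, most likely again reported only as a limit.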

Compound 4, half-maximal inhibitory concentration: 79000 nM
The estimate for compound 4 lay 3.2-fold (0.50 log units) above the measured number; measured number below the stated range.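

For the compounds shown here, the steps among compounds 1, 2 and 3 cannot be read, and this is the first change with a readable direction: in this assay, formyl in place of hydrogen on an aromatic carbon brings an at least 3.1-fold lower number from compound 3 to compound 4 (0.50 log units; beyond the scatter) on the shared core. Compound 4 gives 79000 nM as a true number, the only one of the four that is not a limit. This carbon, next to the ring nitrogen, is therefore a place where a new group shows up in the read-out.

Going by these compounds, compound 3 stands only at a limit, and the full size of the step stays open. On these data alone, whether an amine or a carboxylic acid on this carbon would act like formyl also stays open.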